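Fused Aryl Replaced by Dimethylpiperidine: Microsomal Stability Outlook

The source may report more compounds than this note shows. Statements on the series, on what has been measured and on what is new or still open speak of the compounds shown alone.

Compound 1, `Cc1nc2cc(-c3ccccc3)nn2c(-c2cc(F)c3c(c2C)CCCO3)c1C(OC(C)(C)C)C(=O)O`, in an ADME assay on microsomes from liver (Homo sapiens), read by LC-MS, using NADPH, with a stated time of 10 min, tested at 0.5 uM (on this read-out higher numbers stand for a more stable compound and lower numbers for a less stable compound), gives 93%.
Compound 2, `Cc1nc2cc(-c3ccccc3)nn2c(N2CCC(C)(C)CC2)c1C(OC(C)(C)C)C(=O)O`, in this assay gives 100%.
Compound 3, `Cc1nc2cc(-c3cccc(OCc4ccccc4)c3)nn2c(-c2cc(F)c3c(c2C)CCCO3)c1C(OC(C)(C)C)C(=O)O`, in this assay gives 72%.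

Compound 1 and compound 2 differ by one change, (a group of 8 heavy atoms (7 carbon, 1 nitrogen; one six-membered non-aromatic ring with 1 hetero atom) in place of a group of 12 heavy atoms (10 carbon, 1 oxygen, 1 fluorine; one six-membered non-aromatic ring with 1 hetero atom, one six-membered aromatic ring of carbon only), on an aromatic carbon). In this assay this change gave a number 7 percentage points higher from compound 1 to compound 2 (within the scatter), so the two are not distinguished by the read-out. Compound 1 and compound 3 differ by benzyloxy in place of hydrogen on an aromatic carbon, and here the step was a number 21 percentage points lower from compound 1 to compound 3 (beyond the scatter). Compound 3 is the least stable of the three measured compounds, its steps to both compound 1 and compound 2 lying beyond the scatter.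

Compound 4, `Cc1nc2cc(-c3cccc(OCc4ccccc4)c3)nn2c(N2CCC(C)(C)CC2)c1C(OC(C)(C)C)C(=O)O`, has not yet been measured in this assay. It differs from compound 3 by a group of 8 heavy atoms (7 carbon, 1 nitrogen; one six-membered non-aromatic ring with 1 hetero atom) in place of a group of 12 heavy atoms (10 carbon, 1 oxygen, 1 fluorine; one six-membered non-aromatic ring with 1 hetero atom, one six-membered aromatic ring of carbon only), on an aromatic carbon. This is the same change already seen from compound 1 to compound 2; the place of the change is described in the same words in both pairs, and the two cores differ by benzyloxy in place of hydrogen on an aromatic carbon. Because that earlier step was a number 7 percentage points higher from compound 1 to compound 2 (within the scatter), compound 4 is expected to sit close to compound 3, with an estimated step of a number 6 percentage points higher from compound 3 to compound 4 (within the scatter). With a single precedent and a different core, the expected step carries uncertainty in either direction. On this basis compound 4 is estimated at 78% in this assay, most likely between 62% and 92%.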

Compound 4, percent of the compound remaining: 100%
Compound 4: the middle estimate sits 22 percentage points below what was measured, outside the stated range (above it).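

Carried onto the core bearing benzyloxy, 4,4-dimethylpiperidin-1-yl in place of the group of 12 heavy atoms gave a number 28 percentage points higher from compound 3 to compound 4 (beyond the scatter), so in this assay the size of this step did not carry over unchanged from the core of compound 1: the same change on two cores in this assay, a number 7 percentage points higher (within the scatter) from compound 1 to compound 2 and a number 28 percentage points higher (beyond the scatter) from compound 3 to compound 4, 21 percentage points apart, beyond the scatter of two such steps

Read the other way, benzyloxy in place of hydrogen gave no change at the digits printed from compound 2 to compound 4 (within the scatter), whereas the same change lowered the number on the core of compound 1: the same change on two cores in this assay, a number 21 percentage points lower (beyond the scatter) from compound 1 to compound 3 and no change at the digits printed (within the scatter) from compound 2 to compound 4, 21 percentage points apart, beyond the scatter of two such steps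

These four compounds show that each step depends on the group at the other place, but they give no reason for it and no rule for any other core, and with compound 2 at 100% and compound 4 at 100%, both at the top of the scale of this read-out, they cannot tell how far the 4,4-dimethylpiperidin-1-yl compounds might differ from each other over a longer time.

The compounds shown leave open whether another amine in the same place, such as morpholine or a piperidine without the two methyl groups, would give the same result alongside benzyloxy. They also leave open whether a smaller ether such as methoxy in place of benzyloxy would lower the number on the core of compound 1 as benzyloxy does.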